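A trifluoromethylphenyl in place of a difluorophenyl

The source may hold more compounds than are shown below. What is called first, only, known or untested is meant among the compounds shown, and "the series" means these compounds.

Compound 1 `Cc1ccccc1CNc1nn(-c2ccc(F)cc2F)cc1CNCCN1CCN(C)CC1`: in an ADME assay on Huh-7 cells (Homo sapiens) for cytotoxicity (a higher number here means that more compound is tolerated, a lower number that less compound is tolerated), compound 1 reaches only the assay limit of > 20000 nM.
Compound 2 `CN1CCN(CCNCc2cn(-c3ccc(F)cc3F)nc2-c2ccc(OC(F)(F)F)cc2)CC1`: in this assay compound 2 gives 18000 nM.
Compound 3 `Cc1ccccc1-c1nn(-c2cc(F)ccc2F)cc1CNCCN1CCN(C)CC1`: in this assay compound 3 reaches only the assay limit of > 20000 nM.

Compound 3 therefore stands at the limit, where two of the three values sit (the limit of > 20000 nM in this assay, at which 2 of the 3 values shown sit). Compound 4 `Cc1ccccc1-c1nn(-c2cccc(C(F)(F)F)c2)cc1CNCCN1CCN(C)CC1` differs from compound 3 by 3-(trifluoromethyl)phenyl in place of 2,5-difluorophenyl on an aromatic nitrogen. Within the data shown here, the only measured step, an at least 1.1-fold lower number from compound 1 to compound 2 (0.04 log units; that floor lies within the scatter), exchanged a group on an aromatic carbon rather than on the aromatic nitrogen, so it does not bear directly on this change, and it stayed within the scatter anyway. With no step beyond the scatter anywhere in the set, none is expected here either. Compound 4 is estimated at 20000 nM, with a range from 8000 nM to 50000 nM. That estimate means an expected step of a number no higher from compound 3 to compound 4 (the limit leaves the size open), and the result will most likely again be reported as a limit.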

Compound 4, half-maximal cytotoxic concentration: 18000 nM
For compound 4 the middle estimate is 1.1-fold (0.05 log units) above the measured one; the measured number falls inside the stated range.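

Compound 4 gives the only step shown at this aromatic nitrogen in this assay (an at least 1.1-fold lower number from compound 3 to compound 4 (0.04 log units; that floor lies within the scatter)). Exchanging 2,5-difluorophenyl for the larger 3-(trifluoromethyl)phenyl therefore shows no change beyond the scatter. Going by these compounds, because compound 3 carries only a limit, the full size of the step stays open: the limit of > 20000 nM in this assay, at which 2 of the 4 values shown sit.

Still open, on these data alone, is whether an amine or a carboxylic acid on this phenyl ring, or a longer chain in its place, would change the concentration tolerated. Also open, as far as these compounds go, is whether this exchange would behave alike with the (2-methylbenzyl)amino group of compound 1.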